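A few compounds are considered here, and "the series" means these few. Any claim that something is new, unique, unknown or untested is made for them only; others in the source may bear on it.

Measured so far:
compound 1, `CCCCNC(=S)NC1=C(C#N)C(c2ccc(Cl)cc2Cl)C2=C(CCCC2=O)N1c1ccc(S(N)(=O)=O)cc1`, in a functional assay on Ehrlich cells (Mus musculus) for cytotoxicity, read by trypan blue exclusion, with a stated time of 2 h (on this read-out lower numbers stand for stronger inhibition and higher numbers for weaker inhibition), gives > 100 ug/mL, which is a limit of the assay and not a number.
compound 2, `C=CCNC(=S)NC1=C(C#N)C(c2ccc(Cl)cc2Cl)C2=C(CCCC2=O)N1c1ccc(S(N)(=O)=O)cc1`, in this assay gives > 100 ug/mL, again a limit rather than a number.

Both measured values sit at the same limit, as the limit of > 100 ug/mL in this assay, at which 2 of the 2 values shown sit, records. Going by the values given here, the one measured step, a step that the two limits leave unreadable from compound 1 to compound 2, therefore has no readable size; the two limits simply leave it open. Compound 2 stands at that limit, with nothing below it on the numbers shown.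

Compound 3, `N#CC1=C(NC(=S)Nc2ccccc2)N(c2ccc(S(N)(=O)=O)cc2)C2=C(C(=O)CCC2)C1c1ccc(Cl)cc1Cl`, differs from compound 2 by phenyl in place of allyl on an amide-type nitrogen. Among the compounds with values here, no measured step bears on an aryl group at this nitrogen, and the only step in hand is unreadable, so no size or direction in this assay can be argued beyond the scatter. The estimated step in this assay is a step that the limit leaves unreadable from compound 2 to compound 3. Compound 3 is accordingly expected to come out at about 150 ug/mL, within 60 ug/mL to 400 ug/mL, most probably reported once more as a limit.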

Compound 3, half-maximal inhibitory concentration: 25 ug/mL
Beside the measured number, compound 3's estimate is 6.0-fold (0.78 log units) above it, and the stated range ends above it.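

At this amide-type nitrogen, whose other neighbour is the thiocarbonyl carbon, the group now makes a readable difference in this assay: phenyl in place of allyl gives an at least 4.0-fold lower number from compound 2 to compound 3 (0.60 log units; beyond the scatter), and phenyl in place of butyl gives an at least 4.0-fold lower number from compound 1 to compound 3 (0.60 log units; beyond the scatter). Of the three groups shown at this nitrogen, only phenyl brings a value inside the measurable range, while the step between the two open-chain groups cannot be read. Both readable steps are lower bounds on the true size because compound 1 and compound 2 stop at a limit: the limit of > 100 ug/mL in this assay, at which 2 of the 3 values shown sit.

As far as these compounds go, it remains open whether the aromatic ring itself or simply a ring at this nitrogen matters, which a cyclohexyl or benzyl group would help separate. From the compounds shown here alone, the effect of substituents on the phenyl, such as a methoxy group or a chlorine, is equally open.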